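A few compounds are considered here, and "the series" means these few. Any claim that something is new, unique, unknown or untested is made for them only; others in the source may bear on it.

Measured compounds:
Compound 1, `O=C(c1ccccc1C(F)(F)F)N(/N=N/c1ccc([N+](=O)[O-])cc1Br)c1ccc([N+](=O)[O-])cc1Br`: 13300 nM
Compound 2, `O=C(c1cccc(C(F)(F)F)c1)N(/N=N/c1ccc([N+](=O)[O-])cc1Br)c1ccc([N+](=O)[O-])cc1Br`: 1120 nM
Compound 3, `O=C(c1ccccc1C(F)(F)F)N(/N=N/c1ccc([N+](=O)[O-])cc1Cl)c1ccc([N+](=O)[O-])cc1Cl`: 10600 nM

Compound 1 and compound 3 share most of their structure, but the difference between their cores is not broken down here; in a functional assay on HeLa cells (Homo sapiens) for cytotoxicity, read by MTT assay, with a stated time of 72 h (on this read-out lower numbers stand for stronger inhibition and higher numbers for weaker inhibition), compound 1 and compound 3 give numbers within the scatter of each other. Among the compounds with values here, the only counted change among the measured compounds is 3-(trifluoromethyl)phenyl in place of 2-(trifluoromethyl)phenyl on a carbonyl carbon, which gave a 12-fold lower number from compound 1 to compound 2 (1.07 log units; beyond the scatter).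

Compound 4, `O=C(c1cccc(C(F)(F)F)c1)N(/N=N/c1ccc([N+](=O)[O-])cc1Cl)c1ccc([N+](=O)[O-])cc1Cl`, is not yet measured. It stands to compound 3 as compound 2 stands to compound 1: the change is 3-(trifluoromethyl)phenyl in place of 2-(trifluoromethyl)phenyl on a carbonyl carbon, and the place is the same, a carbonyl carbon whose other neighbours are an amide-type nitrogen. Because the same change gave a 12-fold lower number from compound 1 to compound 2 (1.07 log units; beyond the scatter) on a closely related core, a step of similar size is expected here, with the usual caution that a single precedent carries.

In this assay compound 4 is therefore expected at 1000 nM, with a plausible range from 400 nM to 2500 nM, an expected step of an 11-fold lower number from compound 3 to compound 4 (1.03 log units; beyond the scatter) from compound 3.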

Compound 4, half-maximal inhibitory concentration: 1180 nM
For compound 4 the middle estimate is 1.2-fold (0.07 log units) below the measured one; measured number inside the range.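

In this assay, 3-(trifluoromethyl)phenyl in place of 2-(trifluoromethyl)phenyl on a carbonyl carbon gave a 9.0-fold lower number from compound 3 to compound 4 (0.95 log units; beyond the scatter). Set beside the earlier case, the change carried from one core to the other at much the same size: the same change on two cores in this assay, a 12-fold lower number (1.07 log units; beyond the scatter) from compound 1 to compound 2 and a 9.0-fold lower number (0.95 log units; beyond the scatter) from compound 3 to compound 4, 1.3-fold (0.12 log units) apart, within the scatter of two such steps. Within the data shown here, this shows that, for these two closely related cores in this one assay, the step was transferable, but it rests on only two pairs of compounds and shows neither why the change matters nor whether it would hold on a core that differs more widely.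

The compounds shown leave open how a nitrile or a carboxylic acid would behave in place of the trifluoromethyl group on the phenyl ring attached to the carbonyl carbon. They also leave open whether the same step would appear on a core carrying an amine in place of its nitro groups.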